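The source may report more compounds than this note shows. Statements on the series, on what has been measured and on what is new or still open speak of the compounds shown alone.

Compound 1 `O=C(Nc1cccc([N+](=O)[O-])c1)N1CCN(S(=O)(=O)c2sccc2-c2ccccc2Oc2ccc(O)c(O)c2)CC1` carries the shared core with a 3,4-dihydroxyphenyl group on an oxygen on an aromatic ring. In an ADME assay on HEK-293T cells (Homo sapiens) for cytotoxicity, read by CCK-8 assay, with a stated time of 48 h (a higher number here means a weaker inhibitor, a lower number a stronger inhibitor), compound 1 gives > 20000 nM, which is a limit of the assay rather than a number. Compound 2 `COc1ccc(Oc2ccccc2-c2ccsc2S(=O)(=O)N2CCN(C(=O)Nc3cccc([N+](=O)[O-])c3)CC2)cc1OC` differs from compound 1 in one place only, namely (3,4-dimethoxyphenyl in place of 3,4-dihydroxyphenyl on an oxygen on an aromatic ring). In this assay compound 2 gives > 20000 nM, again a limit of the assay and not a number. The step that the two limits leave unreadable from compound 1 to compound 2 therefore cannot be read as a size, since both ends of it sit at the same limit, as the limit of > 20000 nM in this assay, at which 3 of the 3 values shown sit, records for every value shown so far.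

Compound 3 `CC(C)c1ccc(Oc2ccc(O)c(O)c2)c(-c2ccsc2S(=O)(=O)NCCNC(=O)Nc2cc(C(F)(F)F)cc(C(F)(F)F)c2)c1` has a different core; the difference between the two cores is not broken down here. In this assay compound 3 gives > 20000 nM, once more a limit of the assay and not a number.

Compound 4 `COc1ccc(Oc2ccc(C(C)C)cc2-c2ccsc2S(=O)(=O)NCCNC(=O)Nc2cc(C(F)(F)F)cc(C(F)(F)F)c2)cc1OC` is not yet measured. It differs from compound 3 by 3,4-dimethoxyphenyl in place of 3,4-dihydroxyphenyl on an oxygen on an aromatic ring, the same change that separates compound 1 from compound 2, made on the same kind of place. With every measured value resting at the limit described by the limit of > 20000 nM in this assay, at which 3 of the 3 values shown sit, the expectation for compound 4 is that it too stays above that limit, with an expected step that the limit leaves unreadable from compound 3 to compound 4 that is essentially unreadable. The estimate for compound 4 in this assay is therefore 30000 nM, expected to lie between 15000 nM and 100000 nM.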

Compound 4, half-maximal inhibitory concentration: 12100 nM
Estimate against measurement, compound 4: 2.5-fold (0.39 log units) above, and the stated range ends above it.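

In this assay, placing 3,4-dimethoxyphenyl where 3,4-dihydroxyphenyl stood, on the same oxygen on an aromatic ring, gives an at least 1.6-fold lower number from compound 3 to compound 4 (0.21 log units; that floor lies within the scatter). Compound 3 sits at a limit of the assay and not at a number, so this step is only a floor: the true step may be larger, but the floor alone lies within the usual scatter and does not establish a real drop. Nor does it show that the change carries from one core to another, because the same change on the core of compound 1 cannot be read, so there is no size to set against this one: the limit of > 20000 nM in this assay, at which 3 of the 4 values shown sit.

The compounds shown leave open how the number would move if the two oxygens of the 3,4-dihydroxyphenyl group carried a longer chain such as ethyl, or if an amine or a carboxylic acid stood on that ring instead. They also leave open how large the change from 3,4-dihydroxyphenyl to 3,4-dimethoxyphenyl really is, since that would take a pair on one core with a readable number at both ends.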